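Trifluoromethoxy in Place of Hydrogen on Compound 3

The source may report more compounds than this note shows. Statements on the series, on what has been measured and on what is new or still open speak of the compounds shown alone.

Compound 1 `CN(C)CC[C@H](CSc1ccccc1)Nc1ccc(S(=O)(=O)NC(=O)c2ccc(N3CCN(Cc4ccccc4-c4ccc(Cl)cc4)CC3)cc2)cc1C(F)(F)F` — < 1 nM
Compound 2 `Cc1cc(S(=O)(=O)NC(=O)c2ccc(N3CCN(Cc4ccccc4-c4ccc(Cl)cc4)CC3)cc2)ccc1N[C@H](CCN(C)C)CSc1ccccc1` — < 1 nM
Compound 3 `CN(C)CC[C@H](CSc1ccccc1)Nc1ccc(S(=O)(=O)NC(=O)c2ccc(N3CCN(Cc4ccccc4-c4ccc(Cl)cc4)CC3)cc2)cc1` — < 1 nM

In an assay on isolated protein for displacement of a labelled ligand from Apoptosis regulator Bcl-2 (Homo sapiens), read by fluorescence polarization (on this read-out lower numbers stand for stronger inhibition and higher numbers for weaker inhibition), compound 1 gives < 1 nM, which is a limit of the assay and not a number. Compound 2 gives < 1 nM, again a limit. Compound 3 gives < 1 nM, also a limit. All three sit at the limit of < 1 nM in this assay, at which 3 of the 3 values shown sit, so compound 3 cannot be placed above or below the others. The steps a step that the two limits leave unreadable from compound 1 to compound 3, a step that the two limits leave unreadable from compound 2 to compound 3 and a step that the two limits leave unreadable from compound 1 to compound 2 therefore carry no readable size.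

Compound 4 `CN(C)CC[C@H](CSc1ccccc1)Nc1ccc(S(=O)(=O)NC(=O)c2ccc(N3CCN(Cc4ccccc4-c4ccc(Cl)cc4)CC3)cc2)cc1OC(F)(F)F` differs from compound 3 by trifluoromethoxy in place of hydrogen on an aromatic carbon. Within the data shown here, no measured step reads on this change, so the expected step that the limit leaves unreadable from compound 3 to compound 4 is none beyond the scatter. Compound 4 is expected to give 0.5 nM in this assay, within 0.1 nM to 3 nM, most likely again as a limit.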

Compound 4, inhibition constant: < 1 nM
Compound 4: a limit, no number (the forecaster's own chance of this, stated with the estimate: 85%); the middle value is on the limit's open side.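

In this assay compound 4 gives < 1 nM, a limit. No step from compound 1, compound 2 or compound 3 to compound 4 can be read: the limit of < 1 nM in this assay, at which 4 of the 4 values shown sit.

From the compounds shown here alone, how hydrogen, methyl, trifluoromethyl and trifluoromethoxy on this aromatic carbon rank against one another stays open.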